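The source may report more compounds than this note shows. Statements on the series, on what has been measured and on what is new or still open speak of the compounds shown alone.

Compound 1 `COc1cc(CNC(=S)NCC(COC(=O)C(C)(C)C)Cc2ccc(C)c(C)c2)cc(Br)c1O` and compound 2 `COc1cc(CNC(=S)NCC(COC(=O)C(C)(C)C)Cc2ccc(C)c(C)c2)c(Br)cc1O` are built on the same core and differ in one place, namely (2-bromo-4-hydroxy-5-methoxyphenyl in place of 3-bromo-4-hydroxy-5-methoxyphenyl on a saturated chain carbon bound to an amide-type nitrogen). In an assay on CHO cells for displacement of a labelled ligand from transient receptor potential cation channel subfamily V member 1 (Rattus norvegicus) (on this read-out higher numbers stand for weaker inhibition and lower numbers for stronger inhibition), compound 1 gives 33.1 nM, while compound 2 gives 19.9 nM, a step of a 1.7-fold lower number from compound 1 to compound 2 (0.22 log units; within the scatter). Compound 3 `COc1cc(CNC(=S)NC(CCc2ccc(C)c(C)c2)COC(=O)C(C)(C)C)cc(Br)c1O` rests on another core, and in this assay compound 3 gives 102 nM, the highest of the three numbers. How the core of compound 3 differs from the core of compound 1 is not broken down here.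

Compound 4 `COc1cc(CNC(=S)NC(CCc2ccc(C)c(C)c2)COC(=O)C(C)(C)C)c(Br)cc1O` has not yet been measured. It differs from compound 3 by 2-bromo-4-hydroxy-5-methoxyphenyl in place of 3-bromo-4-hydroxy-5-methoxyphenyl on a saturated chain carbon bound to an amide-type nitrogen, and the place of the change is the same as between compound 1 and compound 2, so this is the same change made on the other core. The expectation for compound 4 rests on compound 1 and compound 2, where the change gave a 1.7-fold lower number from compound 1 to compound 2 (0.22 log units; within the scatter), a step that stayed within the scatter. Compound 4 is therefore expected to follow compound 3 closely, with a step estimated at a 1.6-fold lower number from compound 3 to compound 4 (0.20 log units; within the scatter). In this assay compound 4 is expected to give 65 nM, most likely between 30 nM and 150 nM.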

Compound 4, inhibition constant: 109 nM
Beside the measured number, compound 4's estimate is 1.7-fold (0.22 log units) below it; the range from low to high includes it.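

In this assay, exchanging 3-bromo-4-hydroxy-5-methoxybenzyl for 2-bromo-4-hydroxy-5-methoxybenzyl on the second core gives a 1.1-fold higher number from compound 3 to compound 4 (0.03 log units; within the scatter), so compound 3 and compound 4 cannot be told apart on this read-out. Set beside the earlier step, the change reads alike on the two cores: the same change on two cores in this assay, a 1.7-fold lower number (0.22 log units; within the scatter) from compound 1 to compound 2 and a 1.1-fold higher number (0.03 log units; within the scatter) from compound 3 to compound 4, 1.8-fold (0.25 log units) apart, within the scatter of two such steps. This shows that the change carries from one core to the other without a detectable difference in these two pairs, but it does not show that the change has any real effect of its own on either core, nor that a third core would behave the same way.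

The compounds shown leave open whether a chlorine or an iodine in place of the bromine would give the same picture on these two cores. They also leave open whether the change would read alike with a free alcohol in place of the pivaloyl ester or with a urea in place of the thiourea.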